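The source may report more compounds than this note shows. Statements on the series, on what has been measured and on what is new or still open speak of the compounds shown alone.

Compound 3, `C=CC(=O)N1CCN(Cc2ccc(Nc3nccc(Oc4c(C)cc(/C=C/C#N)cc4C)n3)cc2)CC1`, belongs to a small set of three measured compounds that share one core. Compound 1 is `Cc1cc(/C=C/C#N)cc(C)c1Oc1ccnc(Nc2ccc(CN3CCCN(S(=O)(=O)C(C)C)CC3)cc2)n1` and compound 2 is `Cc1cc(C#N)cc(C)c1Oc1ccnc(Nc2ccc(CN3CCCN(S(C)(=O)=O)CC3)cc2)n1`. In an ADME assay on MT4 cells (Homo sapiens) for cytotoxicity, read by MTT assay (a lower number here means that less compound is tolerated, a higher number that more compound is tolerated), compound 3 gives 5210 nM. In this assay compound 1 gives 4640 nM and compound 2 gives 7850 nM. Compound 3 differs from compound 1 only by an amount within the usual scatter, and from compound 2 likewise by an amount within the scatter, so no ordering among the three can be read from these numbers.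

Compound 4, `Cc1cc(/C=C/C#N)cc(C)c1Oc1ccnc(Nc2ccc(CN3CCCN(S(C)(=O)=O)CC3)cc2)n1`, has not yet been measured in this assay. Its difference from compound 3 is 4-(methylsulfonyl)-1,4-diazepan-1-yl in place of 4-(vinylcarbonyl)piperazin-1-yl on a saturated chain carbon bound to an aromatic carbon. Among the compounds with values here, no measured pair in the set isolates this change, so its size can only be judged from the spread of the three known numbers, which all sit close together. Compound 4 carries the same substituents on the shared core as compound 1 and compound 2 apart from the group named here, and both of those compounds fall within the scatter of compound 3. The step from compound 3 to compound 4 is therefore expected to be a 1.1-fold higher number from compound 3 to compound 4 (0.02 log units; within the scatter), with no direction beyond the scatter. Compound 4 is estimated to give 5500 nM in this assay, within a range from 2500 nM to 12000 nM.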

Compound 4, half-maximal cytotoxic concentration: 17400 nM
Compound 4: middle estimate off by 3.2-fold (0.50 log units), on the low side; the whole stated range lies below it.
By their numbers in this assay, from the lowest: compounds 1, 3 and 2 (each within the scatter of the next); then compound 4.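

Within the data shown here, compound 4 is the first compound to stand apart in this assay, and it does so against each earlier compound through a single change: 4-(methylsulfonyl)-1,4-diazepan-1-yl in place of 4-(vinylcarbonyl)piperazin-1-yl (a 3.3-fold higher number from compound 3 to compound 4 (0.52 log units; beyond the scatter)), 2-cyanoethenyl in place of cyano on an aromatic carbon (a 2.2-fold higher number from compound 2 to compound 4 (0.35 log units; beyond the scatter)), and methyl in place of isopropyl on a sulfonyl sulfur (a 3.8-fold higher number from compound 1 to compound 4 (0.57 log units; beyond the scatter)). The earlier numbers lay within the scatter of one another and gave no sign that the group on the saturated chain carbon mattered, whereas this result shows that exchanging it can move the number beyond the scatter. Compound 1 and compound 2 also carry the seven-membered ring yet stay within the scatter of compound 3, so in these compounds the ring alone does not give the higher number, which appears only where methyl on the sulfonyl sulfur and 2-cyanoethenyl occur together.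

From the compounds shown here alone, it remains open whether methylsulfonyl on a piperazine ring, or an ethyl group on the sulfonyl sulfur, would keep the number of compound 4. Nothing available accounts for the step itself.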